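Moving a fluorine within a fused ring and the half-life

A few compounds are considered here, and "the series" means these few. Any claim that something is new, unique, unknown or untested is made for them only; others in the source may bear on it.

Compound 1 `C=CC(=O)N1CC(NC(=O)COc2ccc(Br)cc2C(=O)N2CC=C(c3ccccc3)C2)C1` and compound 2 `C=CC(=O)N1CC(NC(=O)Cn2cc(C(=O)N3CCc4c(F)cccc4C3)c3cc(Br)ccc32)C1` share an acrylamide-bearing core but carry different side pieces. In a physicochemical assay for pharmacokinetics, read by LC-MS, in phosphate buffer, at pH 7.4, in the presence of a further agent that is not named here (a lower number here means that the compound disappears faster, a higher number that the compound lasts longer), compound 1 gives 1.67 h. In this assay compound 2 gives 1.67 h, so compound 2 stands level with compound 1 at the digits shown, within the usual scatter.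

Compound 3 `C=CC(=O)N1CC(NC(=O)Cn2cc(C(=O)N3CCc4cc(F)ccc4C3)c3cc(Br)ccc32)C1` keeps every atom of compound 2 and differs only in where the fluorine sits: 6-fluoro-1,2,3,4-tetrahydroisoquinolin-2-yl in place of 5-fluoro-1,2,3,4-tetrahydroisoquinolin-2-yl on a carbonyl carbon. Among the compounds with values here, no pair of measured compounds here differs in just this way, so the size of this step is not known from the numbers at hand. Given that compound 1 and compound 2 already agree despite larger differences, the step from compound 2 to compound 3 is expected to be no change at the digits printed from compound 2 to compound 3 (within the scatter), that is, nothing beyond the scatter. Compound 3 is therefore estimated at 1.67 h, with a range from 0.9 h to 3.2 h.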

Compound 3, half-life: 1.67 h
Compound 3: the middle estimate sits on the measured number at the digits printed; low and high end bracket the measured number.
By their numbers in this assay, from the lowest: compounds 1, 2 and 3 (each within the scatter of the next).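

In this assay, moving the fluorine gives no change at the digits printed from compound 2 to compound 3 (within the scatter), so on this carbonyl carbon, 6-fluoro-1,2,3,4-tetrahydroisoquinolin-2-yl and 5-fluoro-1,2,3,4-tetrahydroisoquinolin-2-yl cannot be told apart by half-life. Compound 1 and compound 2 differ in more than one place, so their agreement could not isolate any single change, whereas this pair isolates one: the same atoms, joined differently, at one place. Nothing available here bears on why the half-life responds in this way.

The compounds shown leave open whether this place is as forgiving of other changes, such as a chlorine or a methoxy group in place of the fluorine. On these data alone, it is also open whether a larger change, such as a simple piperidine ring or an added carboxylic acid, would shift the half-life beyond the scatter.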